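One Chloro Removed: From Compound 3 to Compound 4

The source may report more compounds than this note shows. Statements on the series, on what has been measured and on what is new or still open speak of the compounds shown alone.

Of the compounds shown here, three with a shared core have been tested. Compound 1 `N=C(N)N/N=C/c1ccc(/C=C/C(=O)c2cccc(Cl)c2)cc1` gives 80.7% in a functional assay on the whole organism (Ear) for inhibition, with Mus musculus as the target, with a stated time of 30 min, at a dose of 100 mg/kg by the intraperitoneal route; a lower number here means less inhibition, a higher number more inhibition at the dose given (going by the name of the read-out). Compound 2 `N=C(N)N/N=C/c1ccc(/C=C/C(=O)c2ccc(F)cc2)cc1` gives 90.7% in this assay, and compound 3 `N=C(N)N/N=C/c1ccc(/C=C/C(=O)c2ccc(Cl)cc2Cl)cc1` gives 92.5%. Compound 3 holds the highest of the three numbers, but its margin over compound 2 is small (a number 1.8 percentage points higher from compound 2 to compound 3 (within the scatter)), while its margin over compound 1 is larger (a number 11.8 percentage points higher from compound 1 to compound 3 (beyond the scatter)). Between compound 1 and compound 2 the step is a number 10 percentage points higher from compound 1 to compound 2 (within the scatter).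

Compound 4 `N=C(N)N/N=C/c1ccc(/C=C/C(=O)c2ccccc2Cl)cc1` is not yet measured. It differs from compound 3 by hydrogen in place of chloro on an aromatic carbon, so the group on the carbonyl carbon changes from 2,4-dichlorophenyl to 2-chlorophenyl. Within the data shown here, no measured step involves 2-chlorophenyl. The closest guidance comes from compound 1 and compound 2, whose single-substituted groups on that carbon sit within or just beyond the scatter of compound 3, and the step from compound 2 to compound 3 is within the scatter. A step of modest size, downward or none beyond the scatter, is therefore expected for compound 4, namely a number 7.5 percentage points lower from compound 3 to compound 4 (within the scatter). In this assay compound 4 is estimated to give 85%, in a range from 72% to 95%.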

Compound 4, a percentage reported as inhibition, in the whole organism at one dose (the size of the read-out at that dose, not a potency): 84.1%
For compound 4 the middle estimate is 0.9 percentage points above the measured one, within the range that was stated.
By their numbers in this assay, from the lowest: compounds 1, 4, 2 and 3 (each within the scatter of the next, the first and the last beyond it).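

With hydrogen in place of the chloro para to a large group, this assay shows a step that stays within the scatter (a number 8.4 percentage points lower from compound 3 to compound 4 (within the scatter)), so the 2,4-dichlorophenyl group is not shown to differ from the 2-chlorophenyl group at this position. The 2-chlorophenyl group also cannot be told apart from either of the other single-substituted groups (a number 6.6 percentage points lower from compound 2 to compound 4 (within the scatter); a number 3.4 percentage points higher from compound 1 to compound 4 (within the scatter)), which leaves compound 4 within the scatter of compound 1 and of compound 3, even though the step between those two lies beyond it (a number 11.8 percentage points higher from compound 1 to compound 3 (beyond the scatter)). No measurement available here bears on the reason for these results.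

The compounds shown leave open how this assay would respond to an unsubstituted phenyl group or to a methoxy group, an amine or a carboxylic acid on this ring. Because every read-out comes from one dose and one time point, they also leave open whether compounds that cannot be separated here would stay level at lower doses or at other times.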